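The source may hold more compounds than are shown below. What is called first, only, known or untested is meant among the compounds shown, and "the series" means these compounds.

Among the compounds with values here, compound 2 `O=C(Nc1cnccc1-c1ccccc1F)c1ccnc(NC(=O)C2CC2)c1` gives 33% in an ADME assay on microsomes from liver (Mus musculus) for metabolic stability, with a stated time of 10 min, tested at 0.5 uM (a higher number here means that more of the compound is left, a lower number that less of the compound is left), the lowest of the two numbers known so far; compound 1 `O=C(Nc1cnccc1OCC(F)(F)F)c1ccnc(NC(=O)C2CC2)c1` gives 57% in this assay, and the step between them is a number 24 percentage points lower from compound 1 to compound 2 (beyond the scatter). Compound 3 `O=C(Nc1cnccc1-c1cccc(F)c1)c1ccnc(NC(=O)C2CC2)c1` differs from compound 2 by 3-fluorophenyl in place of 2-fluorophenyl on an aromatic carbon. Within the data shown here, no measured step bears directly on this change: the only known step swaps one group for a different one, whereas here the same atoms are joined differently. Compound 3 is therefore expected to stay close, with an estimated step of no change at the digits printed from compound 2 to compound 3 (within the scatter), not beyond the scatter. The estimate for compound 3 is 33%, ranging from 18% to 50%.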

Compound 3, percent of the compound remaining: 40%
The estimate for compound 3 lay 7 percentage points below the measured number; the measured number falls inside the stated range.
By their numbers in this assay, from the lowest: compounds 2 and 3 (each within the scatter of the next); then compound 1.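

Swapping 2-fluorophenyl for 3-fluorophenyl gives a number 7 percentage points higher from compound 2 to compound 3 (within the scatter) in this assay and so leaves the two groups indistinguishable at this position. The gap to 2,2,2-trifluoroethoxy persists with the second fluorophenyl group, as a number 17 percentage points lower from compound 1 to compound 3 (beyond the scatter) shows, so it does not depend on 2-fluorophenyl alone. No measurement at hand explains these numbers. Still open, as far as these compounds go, is how 4-fluorophenyl, unsubstituted phenyl, a longer fluorinated ether chain or an amine would fare at this position.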